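Longer Chain on the Disulfide: What Compound 4 May Give

The source may hold more compounds than are shown below. What is called first, only, known or untested is meant among the compounds shown, and "the series" means these compounds.

Compound 1, `Cc1cn([C@H]2C[C@H](SSc3ccccc3[N+](=O)[O-])[C@@H](CO)O2)c(=O)[nH]c1=O`: in a physicochemical assay for metabolic stability, in the presence of a further agent that is not named here (a lower number here means that the compound disappears faster, a higher number that the compound lasts longer), compound 1 gives < 0.167 h, a limit of the assay.
Compound 2, `Cc1cn([C@H]2C[C@H](SSc3ccc([N+](=O)[O-])cc3)[C@@H](CO)O2)c(=O)[nH]c1=O`: in this assay compound 2 gives < 0.167 h, also a limit.
Compound 3, `CCCCSS[C@H]1C[C@H](n2cc(C)c(=O)[nH]c2=O)O[C@@H]1CO`: in this assay compound 3 gives < 8 h, again a limit.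

Compound 3 stands at the limit of < 8 h in this assay, at which 1 of the 3 values shown sits, while the two nitrophenyl compounds sit at the limit of < 0.167 h in this assay, at which 2 of the 3 values shown sit. Because all three values are limits, the steps a step that the two limits leave unreadable from compound 1 to compound 3 and a step that the two limits leave unreadable from compound 2 to compound 3 cannot be read in size, and the step that the two limits leave unreadable from compound 1 to compound 2 cannot either. Compound 4, `CCCCCCCCSS[C@H]1C[C@H](n2cc(C)c(=O)[nH]c2=O)O[C@@H]1CO`, differs from compound 3 by butyl in place of hydrogen on a saturated chain carbon, four bonds along the chain from a sulfur. Within the data shown here, no measured step changes the length of this chain, so none bears directly on the change. With compound 3 known only as a limit, the expected step that the limit leaves unreadable from compound 3 to compound 4 is small, within the usual scatter. Compound 4 is therefore estimated at 3 h, between 0.5 h and 8 h.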

Compound 4, half-life: < 8 h
Compound 4: only a limit was reported (the forecaster's own chance of this, stated with the estimate: 50%); the middle value lies beyond the limit too.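

Compound 4, like compounds 1, 2 and 3, is known only as a limit, so its steps to those three cannot be read. Open, from the compounds shown here alone, is how long each compound actually lasts in this assay, and whether butyl in place of hydrogen changes that.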